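Tolerance on liver cells: from compound 3 to compound 4

The compounds below may be only part of what the source reports. "The series", "measured", "known", "first", "only" and "open" are said of these compounds alone.

The series shares the core of compound 1 `CC(C)CCn1nc(-c2cccs2)c(O)c(C2=NS(=O)(=O)c3cc(S(C)(=O)=O)ccc3N2)c1=O`; compound 2 `CC(C)CCn1nc(-c2cccs2)c(O)c(C2=NS(=O)(=O)c3cc(S(=O)(=O)N(C)C)ccc3N2)c1=O` carries a variant of the same core. In an ADME assay on Huh-7 cells (Homo sapiens) for cytotoxicity, with a stated time of 72 h (a lower number here means that less compound is tolerated, a higher number that more compound is tolerated), compound 1 has the entry "not determined" (no result reported), and compound 2 has the entry "not determined" (no result reported). Going by the values given here, compound 3 `CC(C)CCn1nc(-c2ccn(C)c2)c(O)c(C2=NS(=O)(=O)c3cc(NS(C)(=O)=O)ccc3N2)c1=O` is the only member with a result in this assay. For compound 3 that result is a limit, > 1000 nM, not a number. This is the limit of > 1000 nM in this assay, at which 1 of the 3 values shown sits. Compound 4 `CCC(C)(C)c1nn(CCC(C)C)c(=O)c(C2=NS(=O)(=O)c3cc(NS(C)(=O)=O)ccc3N2)c1O` differs from compound 3 in one place: 1,1-dimethylpropyl in place of 1-methyl-1H-pyrrol-3-yl on an aromatic carbon. Among the compounds with values here, no step between measured compounds is recorded, so the size of this change in this assay is unknown; the expectation is none beyond the scatter. Compound 4 is therefore expected to sit at 3000 nM, within 1000 nM to 10000 nM. The step that the limit leaves unreadable from compound 3 to compound 4 is expected to be small.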

Compound 4, half-maximal cytotoxic concentration: > 1000 nM
Compound 4: a limit, no number; the forecaster's own chance of this, stated with the estimate: 80%; the middle value is on the limit's open side.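

Going by these compounds alone, compound 3 and compound 4 both give a limit, not a number, so no step between them can be read: the limit of > 1000 nM in this assay, at which 2 of the 4 values shown sit.

The compounds shown leave open whether 1,1-dimethylpropyl in place of 1-methyl-1H-pyrrol-3-yl changes tolerance at all.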